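The compounds below may be only part of what the source reports. "The series", "measured", "known", "first", "only" and "open" are said of these compounds alone.

Compound 1 `C[C@H](NC(=O)CN(c1nc(Cl)nc2[nH]cnc12)C1CC1)C(=O)OCc1ccccc1`: 64.3%. Compound 2 `O=C(CN(c1nc(Cl)nc2[nH]cnc12)C1CC1)N[C@@H](CC(=O)OCc1ccccc1)C(=O)OCc1ccccc1`: 22.4%. Compound 3 `O=C(CN(c1ncnc2c1ncn2C1CCCCO1)C1CC1)N[C@@H](CC(=O)OCc1ccccc1)C(=O)OCc1ccccc1`: 38.2%.

All three were tested in a functional assay on the whole organism (Tail, strain ICR) with Mus musculus as the target, in the tail flick test, with a stated time of 60 min, at a dose of 25 umol/kg by the oral route; on this read-out lower numbers stand for a weaker effect and higher numbers for a stronger effect at the one dose given. Compound 2 gives 22.4%, while compound 1 gives 64.3%, and the step of a number 41.9 percentage points higher from compound 2 to compound 1 (beyond the scatter) goes with the change (hydrogen in place of benzyloxycarbonyl on a saturated chain carbon, two bonds along the chain from an amide-type nitrogen and a carbonyl carbon). Compound 3 carries a different core; how its core differs from the core of compound 2 is not broken down here. In this assay compound 3 gives 38.2%, which stands beyond the scatter from both other numbers.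

Compound 4 `C[C@H](NC(=O)CN(c1ncnc2c1ncn2C1CCCCO1)C1CC1)C(=O)OCc1ccccc1` has not yet been measured. It differs from compound 3 by hydrogen in place of benzyloxycarbonyl on a saturated chain carbon, two bonds along the chain from an amide-type nitrogen and a carbonyl carbon, the same change at the same place that turns compound 2 into compound 1. On that single precedent, compound 4 is expected to move by a number 33.8 percentage points higher from compound 3 to compound 4 (beyond the scatter). Because the earlier step was a number 41.9 percentage points higher from compound 2 to compound 1 (beyond the scatter), a gain of similar size is expected, yet because compound 3 already starts from 38.2%, a percentage read-out leaves less room to rise, so the expectation is tempered. Compound 4 is estimated at 72%, within a range from 50% to 92%.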

Compound 4, a percentage reported as activity, at one dose (the size of the read-out at that dose, not a potency): 53%
Estimate against measurement, compound 4: 19 percentage points above; the measured number falls inside the stated range.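

In this assay, hydrogen in place of benzyloxycarbonyl on a saturated chain carbon again goes with a higher number, a number 14.8 percentage points higher from compound 3 to compound 4 (beyond the scatter), so the direction of the change carries over from one core to the other. The size of the gain does not carry over, as the two steps set side by side show: the same change on two cores in this assay, a number 41.9 percentage points higher (beyond the scatter) from compound 2 to compound 1 and a number 14.8 percentage points higher (beyond the scatter) from compound 3 to compound 4, 27.1 percentage points apart, beyond the scatter of two such steps Two pairs on two cores do not show which difference between the cores goes with the smaller step, nor do they show whether the direction would hold on any further core, and a read-out at one dose says nothing about potency.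

The compounds shown leave open how a free carboxylic acid in place of benzyloxycarbonyl would read in this assay. They also leave open how a longer chain in place of the methyl left on that saturated chain carbon would compare on either core.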